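The compounds below may be only part of what the source reports. "The series", "measured", "known", "first", "only" and "open" are said of these compounds alone.

Compound 1, with the structure `Cc1cc(NC(=O)c2cccc(C(F)(F)F)c2)ccc1NS(=O)(=O)C(F)(F)F`, is the reference point of this small set. In an ADME assay on RAW264.7 cells (Mus musculus) for cytotoxicity, read by MTT assay, with a stated time of 48 h (on this read-out higher numbers stand for weaker inhibition and lower numbers for stronger inhibition), compound 1 gives 8720 nM. Compound 2, `Cc1cc(NC(=O)c2cc(C(F)(F)F)cc(C(F)(F)F)c2)ccc1NS(=O)(=O)C(F)(F)F`, carries one more group on the same core, the change being (trifluoromethyl in place of hydrogen on an aromatic carbon), and in this assay compound 2 gives 40700 nM, so that the step of a 4.7-fold higher number from compound 1 to compound 2 (0.67 log units; beyond the scatter) is a move toward weaker inhibition. Compound 3, `CCS(=O)(=O)Nc1ccc(NC(=O)c2cccc(C(F)(F)F)c2)cc1OC`, rests on a different core; the difference between the two cores is not broken down here. In this assay compound 3 gives 84800 nM, the highest of the three numbers. Compound 4, `CCS(=O)(=O)Nc1ccc(NC(=O)c2cc(C(F)(F)F)cc(C(F)(F)F)c2)cc1OC`, is not yet measured. It differs from compound 3 by trifluoromethyl in place of hydrogen on an aromatic carbon, which is the same change as that from compound 1 to compound 2, and the words describing its place are identical. Because the step of a 4.7-fold higher number from compound 1 to compound 2 (0.67 log units; beyond the scatter) lay beyond the scatter, the step from compound 3 to compound 4 is expected to be of a similar size, about a 2.9-fold higher number from compound 3 to compound 4 (0.47 log units; beyond the scatter). On this basis compound 4 is estimated at 250000 nM, with a likely range from 100000 nM to 600000 nM, and a real chance that this assay reports only a limit rather than a number.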

Compound 4, half-maximal inhibitory concentration: > 250000 nM
Compound 4: a limit, no number; the forecaster's own chance of this, stated with the estimate: 50%; the middle value sits exactly at the limit.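

In this assay, the step of an at least 2.9-fold higher number from compound 3 to compound 4 (0.46 log units; beyond the scatter) runs in the same direction as the earlier one on the core of compound 1, so on these two cores adding the second trifluoromethyl group moves the number toward weaker inhibition both times. Compound 4 gives > 250000 nM, which is a limit of the assay and not a number. The direction of the change therefore carries from one core to the other in this single pair, but its size cannot be said to carry over, and two cores do not establish a rule for the series: the same change on two cores in this assay, a 4.7-fold higher number (0.67 log units; beyond the scatter) from compound 1 to compound 2 and an at least 2.9-fold higher number (0.46 log units; beyond the scatter) from compound 3 to compound 4; the limit leaves it open whether they differ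

The compounds shown leave open whether a nitrile, an amine or a carboxylic acid in place of the second trifluoromethyl group would shift the number in the same direction on both cores. On these data alone, they also leave unseparated the parts by which the core of compound 1 differs from that of compound 3, so the contribution of each part to the numbers remains unknown.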